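One Aryl Substituent Changed: Fluoro to Methoxy

A few compounds are considered here, and "the series" means these few. Any claim that something is new, unique, unknown or untested is made for them only; others in the source may bear on it.

Compound 1 `O=S(=O)(Nc1ccccc1NS(=O)(=O)c1ccccc1)c1ccccc1`: 32200 nM
Compound 2 `O=S(=O)(Nc1ccccc1NS(=O)(=O)c1ccc(F)cc1)c1ccc(F)cc1`: 28300 nM

Of the compounds shown here, two have been measured in an assay for binding affinity to protein lin-28 homolog A (Mus musculus), with a stated time of 1 h; on this read-out higher numbers stand for weaker inhibition and lower numbers for stronger inhibition. Compound 1 gives 32200 nM, and compound 2 gives 28300 nM. Compound 2 has the lower of the two numbers, but the gap to compound 1 lies within the scatter of this kind of measurement, so the two compounds cannot be told apart on this assay, and neither can be called the more potent one.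

The next compound, compound 3 `COc1ccc(S(=O)(=O)Nc2ccccc2NS(=O)(=O)c2ccc(F)cc2)cc1`, is built from compound 2 by a single change: methoxy in place of fluoro on an aromatic carbon. Both groups are small, and the change leaves the rest of the structure untouched. Going by the values given here, no step between two measured compounds is available that would show how much such a change moves the number on this assay. With only the two measured values as a guide, and both of them weak, the expected step from compound 2 to compound 3 is small, a 1.1-fold lower number from compound 2 to compound 3 (0.05 log units; within the scatter), in no clear direction and probably not beyond the scatter.

The estimate for compound 3 on this assay is therefore 25000 nM, with a likely range from 8000 nM to 80000 nM.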

Compound 3, half-maximal inhibitory concentration: 17200 nM
Compound 3: middle estimate off by 1.5-fold (0.16 log units), on the high side; the measured number falls inside the stated range.
By their numbers in this assay, from the lowest: compounds 3, 2 and 1 (each within the scatter of the next).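

Going by these compounds alone, this is the first step measured at this position, and in this assay it reads a 1.6-fold lower number from compound 2 to compound 3 (0.22 log units; within the scatter). Methoxy brings one more heavy atom than fluoro and a hydrogen-bond acceptor, yet this swap from 4-fluorophenyl to 4-methoxyphenyl does not separate compound 3 from compound 2 on this read-out, so for now the two must be treated as alike, and the position can carry either group with no change that stands out from the scatter. Nothing available explains the size of this step or says which feature of either group matters for the result.

The compounds shown leave open whether a more different group at this position, such as an amine, a carboxylic acid or a longer chain like butoxy, would move the number beyond the scatter. They also leave open what methoxy would do on the other 4-fluorophenyl group, which stays unchanged in compound 3, and whether placing methoxy on both aryl groups would give a step that can be told apart from the scatter.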